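Swapping a triazole for a pyrazole on a shared aryl core

The source may hold more compounds than are shown below. What is called first, only, known or untested is meant among the compounds shown, and "the series" means these compounds.

Compound 2 `c1ccc(-c2nc[nH]n2)c(NCC2=NCCN2)c1` carries a 1H-1,2,4-triazol-3-yl group and gives 0.794 nM in an in vitro functional assay on cells (Fibroblast) for agonist activity at Alpha-1A adrenergic receptor (Homo sapiens); on this read-out lower numbers stand for an effect already at smaller amounts and higher numbers for an effect only at larger amounts of compound. Among the three measured compounds it holds the lowest number: compound 1 `Cn1nccc1-c1ccccc1NCC1=NCCN1` gives 10 nM, and compound 3 `CCn1ccc(-c2ccccc2NCC2=NCCN2)n1` gives 25.1 nM, both well beyond the scatter from compound 2.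

Compound 4 `c1ccc(-c2cn[nH]c2)c(NCC2=NCCN2)c1` is not yet measured. It differs from compound 2 in one place: 1H-pyrazol-4-yl in place of 1H-1,2,4-triazol-3-yl on an aromatic carbon.

Within the data shown here, one measured step bears on this change. Going a 13-fold lower number from compound 1 to compound 2 (1.10 log units; beyond the scatter) shows that a 1-methyl-1H-pyrazol-5-yl group on this aromatic carbon gives a far higher number than the triazole. Compound 3, which carries a 1-ethyl-1H-pyrazol-3-yl group, also sits far above compound 2, although no single-step comparison links it to compound 2. Both pyrazoles seen so far therefore come out worse than the triazole, but both carry an alkyl group where compound 4 keeps a hydrogen-bond donor, as the triazole does.

A step towards a higher number is therefore expected for compound 4, likely smaller than the step seen from compound 1 to compound 2. The expected change from compound 2 is a 5.0-fold higher number from compound 2 to compound 4 (0.70 log units; beyond the scatter). Compound 4 is estimated at 4 nM, within a range of 1.5 nM to 15 nM.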

Compound 4, half-maximal effective concentration: 1.26 nM
The estimate for compound 4 lay 3.2-fold (0.50 log units) above the measured number; the measured number lies below the stated range.
By their numbers in this assay, from the lowest: compounds 2 and 4 (each within the scatter of the next); then compound 1; then compound 3.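

In this assay the change from 1H-1,2,4-triazol-3-yl to 1H-pyrazol-4-yl gives a 1.6-fold higher number from compound 2 to compound 4 (0.20 log units; within the scatter), so on this aromatic carbon the two rings cannot be told apart, even though one five-membered aromatic ring has 3 hetero atoms and the other has 2. The other new comparison gives a 7.9-fold lower number from compound 1 to compound 4 (0.90 log units; beyond the scatter), which shows that a pyrazole at this place does not always bring a high number: the 1H-pyrazol-4-yl group in compound 4 keeps the number within the scatter of the triazole, while the 1-methyl-1H-pyrazol-5-yl group in compound 1 does not. No measurement is available that would explain either comparison.

The compounds shown leave open whether the methyl group or the point of attachment of the ring sets the gap between compound 1 and compound 4, as these two groups differ in both respects, and a 1-methyl-1H-pyrazol-4-yl group would help to separate the two. From the compounds shown here alone, it also remains open how groups outside this set of five-membered rings, such as a carboxylic acid or a primary amide, would behave on the same aromatic carbon.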